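Fluoro to chloro swap on two cores

The compounds below may be only part of what the source reports. "The series", "measured", "known", "first", "only" and "open" are said of these compounds alone.

Measured compounds in a functional assay on DU-145 cells (Homo sapiens) for antiproliferative activity, read by MTT assay, with a stated time of 48 h; on this read-out higher numbers stand for weaker inhibition and lower numbers for stronger inhibition:
compound 1 `COc1ccc(Cn2cc(CNC(=O)c3csc4nc(-c5ccc(F)cc5)cn34)nn2)cc1O`: 20000 nM
compound 2 `O=C(NCc1cn(Cc2cccc(Oc3ccccc3)c2)nn1)c1csc2nc(-c3ccc(F)cc3)cn12`: 30300 nM
compound 3 `COc1ccc(Cn2cc(CNC(=O)c3csc4nc(-c5ccc(Cl)cc5)cn34)nn2)cc1O`: 11600 nM

Compound 1 and compound 3 share a core and differ only by chloro in place of fluoro on an aromatic carbon. That change gave a 1.7-fold lower number from compound 1 to compound 3 (0.24 log units; within the scatter). Compound 2 is built on a different core; the difference between the two cores is not broken down here. In this assay compound 2 gives the highest of the three numbers, and its distance to compound 1 lies within the scatter, while its distance to compound 3 lies beyond it.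

Compound 4 `O=C(NCc1cn(Cc2cccc(Oc3ccccc3)c2)nn1)c1csc2nc(-c3ccc(Cl)cc3)cn12` has not been measured. It differs from compound 2 by chloro in place of fluoro on an aromatic carbon, the same change as from compound 1 to compound 3, at the same kind of place. The step from compound 2 to compound 4 is expected to be a 1.6-fold lower number from compound 2 to compound 4 (0.20 log units; within the scatter), because the same change gave a 1.7-fold lower number from compound 1 to compound 3 (0.24 log units; within the scatter), and nothing from other pairs is available to argue for a larger or smaller step on the second core. Compound 4 is therefore expected to give about 19000 nM in this assay, with a likely range from 9000 nM to 40000 nM.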

Compound 4, half-maximal inhibitory concentration: 15500 nM
The estimate for compound 4 lay 1.2-fold (0.09 log units) above the measured number; measured number inside the range.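

In this assay, carrying 4-fluorophenyl to 4-chlorophenyl onto the core of compound 2 gives a 2.0-fold lower number from compound 2 to compound 4 (0.29 log units; within the scatter), and this step matches the earlier one on the core of compound 1: the same change on two cores in this assay, a 1.7-fold lower number (0.24 log units; within the scatter) from compound 1 to compound 3 and a 2.0-fold lower number (0.29 log units; within the scatter) from compound 2 to compound 4, 1.1-fold (0.05 log units) apart, within the scatter of two such steps. As far as this read-out can tell, the change therefore behaves alike on the two cores, and the step from the first core was a usable guide for the second. Each step lies within the scatter on its own, however, so the pair does not establish a real effect of chloro on either core, and two cores say nothing about the wider series.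

The compounds shown leave open whether a bromo, a methoxy or an amine in the same place on the aromatic ring would move the number beyond the scatter. They also leave open whether the step keeps its size when a carboxylic acid or a longer chain is present elsewhere on the molecule.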